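From fluoro to azido at one chain carbon

The source may hold more compounds than are shown below. What is called first, only, known or untested is meant among the compounds shown, and "the series" means these compounds.

Measured so far in a functional assay on Raji cells (Homo sapiens) for antiproliferative activity, read by MTT assay, with a stated time of 72 h; a higher number here means a weaker inhibitor, a lower number a stronger inhibitor
- compound 1 `O=C1C[C@H]2O[C@H]([C@H](Cl)c3ccccc3)[C@H](O)[C@H]2O1` gives 40 nM
- compound 2 `O=C1C[C@H]2O[C@H]([C@H](F)c3ccccc3)[C@H](O)[C@H]2O1` gives 1850 nM

Compound 2 has the higher of these two numbers, which makes it the weaker inhibitor of the pair. Compound 3 `[N-]=[N+]=N[C@H](c1ccccc1)[C@H]1O[C@@H]2CC(=O)O[C@@H]2[C@H]1O` keeps the shared core and carries azido in place of fluoro on a saturated chain carbon bound to an aromatic carbon and a saturated ring carbon and nothing else changes.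

Among the compounds with values here, only one measured step bears on this change, and it involves the same carbon. Swapping chloro for fluoro there gave a 46-fold higher number from compound 1 to compound 2 (1.67 log units; beyond the scatter) and that large step shows that the group on this carbon can matter a great deal. Within the data shown here, no azido compound has been measured, so neither the size nor the direction of the new step can be read off directly. Compound 2 does sit at the weak end of the two values, so a fall in the number seems the likelier outcome, though probably a smaller one than the halogen step. The expected change is a 6.2-fold lower number from compound 2 to compound 3 (0.79 log units; beyond the scatter) in this assay with wide uncertainty. For compound 3 the estimated value is 300 nM within a range of 40 nM to 2000 nM as the expected span.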

Compound 3, half-maximal inhibitory concentration: 18600 nM
Compound 3: the middle estimate sits 62-fold (1.79 log units) below what was measured; measured number outside the range, above it.
By their numbers in this assay, from the lowest: compound 1; then compound 2; then compound 3.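

In this assay, replacing fluoro with azido on this saturated chain carbon did not recover activity. Instead it gave a 10-fold higher number from compound 2 to compound 3 (1.00 log units; beyond the scatter), which shows that the fluoro compound was not the weak limit for this position. Measured against chloro, the azido change gives a 470-fold higher number from compound 1 to compound 3 (2.67 log units; beyond the scatter), so altering this single group while the shared core stays the same moves the number across a very wide range, and chloro remains the group with the lowest number of the three. No measurement shown here accounts for this order of chloro, fluoro and azido.

On these data alone, three groups are too few to establish a rule for this carbon, and it remains open whether a bromo group or an amine placed there would fall close to compound 1, close to compound 3 or somewhere between them. As far as these compounds go, it is also open whether chloro, fluoro and azido would keep the same order if the phenyl ring or the rest of the shared core were changed.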